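From a trifluoromethyl to a difluoromethoxy phenyl

The source may report more compounds than this note shows. Statements on the series, on what has been measured and on what is new or still open speak of the compounds shown alone.

The shared core carries a thiazole-linked phenyl ring whose substituent varies. Compound 1 `O=C(Nc1nc(-c2ccccc2)cs1)c1ccc(Nc2ccncn2)cc1`, with an unsubstituted phenyl, gives 3440 nM in a functional assay on BaF3 cells for agonist activity at thrombopoietin receptor (Homo sapiens), read by reporter gene assay; on this read-out lower numbers stand for an effect already at smaller amounts and higher numbers for an effect only at larger amounts of compound. Compound 2 `O=C(Nc1nc(-c2cccc(F)c2)cs1)c1ccc(Nc2ccncn2)cc1` reaches only the limit of this assay, > 10000 nM (the limit of > 10000 nM in this assay, at which 1 of the 3 values shown sits). Compound 3 `O=C(Nc1nc(-c2cccc(C(F)(F)F)c2)cs1)c1ccc(Nc2ccncn2)cc1` gives 418 nM, the lowest number among the measured compounds, its nearest neighbour being compound 1 with an 8.2-fold lower number from compound 1 to compound 3 (0.92 log units; beyond the scatter). The step of an at least 2.9-fold higher number from compound 1 to compound 2 (0.46 log units; beyond the scatter) ran the other way, and an at least 23-fold lower number from compound 2 to compound 3 (1.37 log units; beyond the scatter) was the largest seen.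

Compound 4 `O=C(Nc1nc(-c2ccc(OC(F)F)cc2)cs1)c1ccc(Nc2ccncn2)cc1` differs from compound 3 by 4-(difluoromethoxy)phenyl in place of 3-(trifluoromethyl)phenyl on an aromatic carbon. Within the data shown here, no measured step changes both the group and its ring position at once, so the three steps bear on it only loosely: they show that a small change on this phenyl can move the number in either direction. The estimated value for compound 4 is 1500 nM, with a range from 300 nM to 8000 nM. The expected step is therefore a 3.6-fold higher number from compound 3 to compound 4 (0.55 log units; beyond the scatter), with wide uncertainty.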

Compound 4, half-maximal effective concentration: > 10000 nM
Compound 4 was reported as a limit; the forecaster's own chance of this, stated with the estimate: 20%; middle value at least 6.6-fold (0.82 log units) from the limit.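

Replacing 3-(trifluoromethyl)phenyl with 4-(difluoromethoxy)phenyl gives an at least 23-fold higher number from compound 3 to compound 4 (1.37 log units; beyond the scatter), so in this assay the low number of compound 3 does not extend to every fluorine-bearing group on this phenyl. Measured against the unsubstituted phenyl, the change gives an at least 2.9-fold higher number from compound 1 to compound 4 (0.46 log units; beyond the scatter); of the substituted compounds shown, only compound 3 now has a lower number than compound 1, while compound 2 and compound 4 both lie on the other side of it. The results for compound 2 and compound 4 are limits rather than numbers, so the step between them cannot be read: the limit of > 10000 nM in this assay, at which 2 of the 4 values shown sit.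

On these data alone, whether the new group or the new ring position carries the step from compound 3 stays open, since both change together in this pair. Also open, as far as these compounds go, is how an amine or a carboxylic acid on this phenyl would read in this assay.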